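Ketone aryl swap on the quinoline enone series

A few compounds are considered here, and "the series" means these few. Any claim that something is new, unique, unknown or untested is made for them only; others in the source may bear on it.

Two compounds of this series have numbers in a functional assay on MCF7 cells (Homo sapiens) for antiproliferative activity, read by XTT assay, with a stated time of 72 h; on this read-out higher numbers stand for weaker inhibition and lower numbers for stronger inhibition. Compound 1 `COc1ccc(-c2cc3ccccc3nc2/C=C/C(=O)c2ccccc2)cc1` carries a phenyl on the carbonyl carbon; in this assay compound 1 gives 4040 nM. Compound 2 `COc1ccc(-c2cc3ccccc3nc2/C=C/C(=O)c2ccc(Br)s2)cc1` carries 5-bromothiophen-2-yl in that place; in this assay compound 2 gives 910 nM. Going by the values given here, the single measured step, a 4.4-fold lower number from compound 1 to compound 2 (0.65 log units; beyond the scatter), is the only guide available, and on it compound 2 stands lowest of the two numbers, with compound 1 as its nearest neighbour.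

Compound 3 `COc1ccc(-c2cc3ccccc3nc2/C=C/C(=O)c2cnc(N)nc2C)cc1` is the next member. The change from compound 2 is 2-amino-4-methylpyrimidin-5-yl in place of 5-bromothiophen-2-yl on a carbonyl carbon. Among the compounds with values here, no measured step covers a move from 5-bromothiophen-2-yl to 2-amino-4-methylpyrimidin-5-yl, or to any ring with hydrogen-bond donors on the carbonyl carbon; the phenyl to bromothiophene step shows only that this position responds to change. The expectation for compound 3 is therefore a step of a 3.3-fold higher number from compound 2 to compound 3 (0.52 log units; beyond the scatter) in this assay, back toward or beyond the number of compound 1, with wide uncertainty. Compound 3 is estimated at 3000 nM, with a range from 800 nM to 12000 nM.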

Compound 3, half-maximal inhibitory concentration: > 10000 nM
Compound 3: no number, only a limit; the forecaster's own chance of this, stated with the estimate: 15%; middle value at least 3.3-fold (0.52 log units) from the limit.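

In this assay compound 3 stands as a limit of the assay and not as a number: the limit of > 10000 nM in this assay, at which 1 of the 3 values shown sits. The ring on the carbonyl carbon now moves the number in both directions, since the replacement of 5-bromothiophen-2-yl by 2-amino-4-methylpyrimidin-5-yl gives an at least 10-fold higher number from compound 2 to compound 3 (1.04 log units; beyond the scatter), and the comparison with the phenyl gives an at least 2.4-fold higher number from compound 1 to compound 3 (0.39 log units; beyond the scatter). The earlier pair showed only a drop in the number, whereas compound 3 shows that a ring on this carbon can also end up with weaker inhibition than the phenyl of compound 1, with the true size of the loss left unfixed by the limit.

The change to compound 3 alters ring size, hetero atoms, the amine and the methyl together, so the compounds shown cannot assign the loss to any one of these. Also open, going by these compounds, is how a plain pyrimidin-5-yl without the amine and the methyl, or a thiophen-2-yl without the bromine, would read on this carbonyl carbon.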